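Cyclohexyl for pyridin-4-yl on an amide nitrogen

This account rests on a few compounds, and the source may have more. Where it says the series, first, only, none or still open, it means among the compounds named here.

Measured so far in an ADME assay on MRC5 cells (Homo sapiens) for inhibition, with a stated time of 72 h (on this read-out lower numbers stand for an effect already at smaller amounts and higher numbers for an effect only at larger amounts of compound), with each result a limit of the assay
- Compound 1 `COc1cccc(OC)c1C(=O)Nc1c[nH]nc1C(=O)NCc1ncccc1C` gives > 50000 nM (a limit)
- Compound 2 `COCCNC(=O)c1n[nH]cc1NC(=O)c1c(OC)cccc1OC` gives > 50000 nM (a limit)
- Compound 3 `COc1cccc(OC)c1C(=O)Nc1c[nH]nc1C(=O)Nc1ccncc1` gives > 50000 nM (a limit)

Compound 3 has no exact number and stands at the limit of > 50000 nM in this assay, at which 3 of the 3 values shown sit, like the other two compounds. Compound 4 `COc1cccc(OC)c1C(=O)Nc1c[nH]nc1C(=O)NC1CCCCC1` keeps the shared core but carries cyclohexyl in place of pyridin-4-yl on an amide-type nitrogen. Among the measured compounds shown here, the steps that bear on this are a step that the two limits leave unreadable from compound 1 to compound 3 and a step that the two limits leave unreadable from compound 2 to compound 3 and neither offers a size to carry over. No clear direction is expected, and the estimated step is a number no higher from compound 3 to compound 4 (the limit leaves the size open) with neither direction favoured. Compound 4 is estimated at 50000 nM with an expected range from 20000 nM to 100000 nM and is expected to be reported most likely as a limit again.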

Compound 4, half-maximal effective concentration: 35000 nM
Compound 4: the middle estimate sits 1.4-fold (0.15 log units) above what was measured; measured number inside the range.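

In this assay compound 4 with cyclohexyl on the amide-type nitrogen gives the only exact number among the compounds shown. The other three compounds each remain at a limit: the limit of > 50000 nM in this assay, at which 3 of the 4 values shown sit. The steps are an at least 1.4-fold lower number from compound 3 to compound 4 (0.15 log units; that floor lies within the scatter) and an at least 1.4-fold lower number from compound 2 to compound 4 (0.15 log units; that floor lies within the scatter) and an at least 1.4-fold lower number from compound 1 to compound 4 (0.15 log units; that floor lies within the scatter) and each is only a floor, so its true size cannot be read.

Going by these compounds, whether phenyl or cyclopentyl on this nitrogen would also give an exact number remains open. So does whether a larger step lies hidden behind the limits.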